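A few compounds are considered here, and "the series" means these few. Any claim that something is new, unique, unknown or untested is made for them only; others in the source may bear on it.

Compound 1, `N=C(N)c1ccc2cc(-c3cccc(OCCCCCCOc4ccccc4)c3)oc2c1`, gives 4300 nM in an ADME assay on L6 cells (Rattus norvegicus) for cytotoxicity, read by resazurin assay, with a stated time of 70 h; a lower number here means a stronger inhibitor, a higher number a weaker inhibitor. Compound 2, `CC(C)NC(=N)c1ccc2oc(-c3ccc(OCCCCOc4ccccc4)cc3)cc2c1`, gives 6900 nM. Compound 3, `c1ccc(OCCCCOc2ccc(-c3cc4cc(C5=NCCN5)ccc4o3)cc2)cc1`, gives 2900 nM.

Compound 3 sits at the low end of these three numbers, with compound 1 within the scatter of it and compound 2 beyond it. Going by the values given here, the only one-place step among them, a 2.4-fold lower number from compound 2 to compound 3 (0.38 log units; beyond the scatter), changes the group on the aromatic carbon of the shared core, not the chain. Compound 4, `c1ccc(OCCCCCOc2ccc(-c3cc4cc(C5=NCCN5)ccc4o3)cc2)cc1`, differs from compound 3 by phenoxymethyl in place of phenoxy on a saturated chain carbon, four bonds along the chain from an oxygen on an aromatic ring. Among the compounds with values here, no measured step alters the chain alone, so nothing bears directly on this change, and compound 4 is expected to show no step beyond the scatter, a 1.0-fold higher number from compound 3 to compound 4 (0.01 log units; within the scatter). The estimate for compound 4 is 3000 nM, between 1500 nM and 6000 nM.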

Compound 4, half-maximal inhibitory concentration: 900 nM
Compound 4: the middle estimate sits 3.3-fold (0.52 log units) above what was measured; measured number outside the range, below it.
By their numbers in this assay, from the lowest: compound 4; then compounds 3, 1 and 2 (each within the scatter of the next, the first and the last beyond it).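

In this assay, phenoxymethyl in place of phenoxy on a saturated chain carbon, four bonds along the chain from an oxygen on an aromatic ring, gives a 3.2-fold lower number from compound 3 to compound 4 (0.51 log units; beyond the scatter). This is the first step shown that changes the chain alone, and it shows that the chain, not only the group on the aromatic carbon of the shared core, can move this number beyond the scatter. No measurement here explains the step.

Going by these compounds, a longer chain on this same core remains open, so a single step cannot show whether the number keeps falling or turns back. Also open, on these data alone, is whether an amine or a carboxylic acid on the end phenyl ring would shift it.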